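This account rests on a few compounds, and the source may have more. Where it says the series, first, only, none or still open, it means among the compounds named here.

Compound 1 `N=C(N)Nc1cccc(C(=O)NNC(=O)NC(CC(=O)O)c2ccc(Cl)cc2)c1` and compound 2 `N=C(N)Nc1cccc(C(=O)NNC(=O)NC(CC(=O)O)c2ccc(Br)cc2)c1` share one core and differ at a single point: bromo in place of chloro on an aromatic carbon. In a physicochemical assay for lipophilicity (a higher number here means a more lipophilic compound, a lower number a more polar compound), compound 1 gives 1.26, and compound 2 gives 1.53; the step is a number 0.27 log units higher from compound 1 to compound 2 (within the scatter). Compound 3 `O=C(O)CC(CC(=O)NNC(=O)CCCCNc1ccccn1)c1ccc(Cl)cc1` is built on another core, and the difference between the two cores is not broken down here. In this assay compound 3 gives 2.63, the highest of the three numbers. Compound 4 `O=C(O)CC(CC(=O)NNC(=O)CCCCNc1ccccn1)c1ccc(Br)cc1` has not yet been measured. Compound 4 differs from compound 3 by the same change, in the same surroundings: bromo in place of chloro on an aromatic carbon. The expected step is a number 0.27 log units higher from compound 3 to compound 4 (within the scatter), which rests on the earlier measured step of a number 0.27 log units higher from compound 1 to compound 2 (within the scatter). For compound 4 the estimate in this assay is 2.9, expected to fall between 2.55 and 3.25.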

Compound 4, partition coefficient: 2.9
Compound 4: the middle estimate sits on the measured number at the digits printed, and the stated range covers the measured number.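

In this assay bromo in place of chloro gives a number 0.27 log units higher from compound 3 to compound 4 (within the scatter) and on the other core gave a number 0.27 log units higher from compound 1 to compound 2 (within the scatter) so the two steps match at the digits printed. Each step lies within the scatter, so neither pair separates bromo from chloro, and two cores cannot show that the step would hold on a third. No measurement here explains why the two steps match.

The compounds shown leave open how fluoro, methyl or trifluoromethyl in the same place on the aromatic ring would read in this assay. They also leave open whether the step would hold with an ester or a primary amide in place of the carboxylic acid.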